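Acetyl on the sulfonamide nitrogen of a pyrazole sulfonamide

The compounds below may be only part of what the source reports. "The series", "measured", "known", "first", "only" and "open" are said of these compounds alone.

Measured compounds:
compound 1 `COc1ccc(OC)c(-c2cc(-c3ccc(Cl)cc3)nn2-c2ccc(S(=O)(=O)NC(C)=O)cc2)c1` with 19400 nM
compound 2 `NS(=O)(=O)c1ccc(-n2nc(-c3ccccc3)cc2-c2cc(O)ccc2O)cc1` with 86600 nM
compound 3 `NS(=O)(=O)c1ccc(-n2nc(-c3ccc(Cl)cc3)cc2-c2cc(O)ccc2O)cc1` with 17800 nM

These three compounds were tested in a functional assay on cells (Cancer cell lines, Homo sapiens) for cytotoxicity, read by sulforhodamine B assay, with a stated time of 48 h; on this read-out higher numbers stand for weaker inhibition of growth and lower numbers for stronger inhibition of growth. Compound 3 gives the lowest number of the three. Within the data shown here, compound 1 lies close to it, within the scatter, while compound 2 lies beyond it: the step of a 4.9-fold lower number from compound 2 to compound 3 (0.69 log units; beyond the scatter) is the only one-place change measured here, chloro in place of hydrogen on an aromatic carbon.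

Compound 4 `CC(=O)NS(=O)(=O)c1ccc(-n2nc(-c3ccc(Cl)cc3)cc2-c2cc(O)ccc2O)cc1` has not been measured. Its change from compound 3 is acetyl in place of hydrogen on a sulfonamide nitrogen. Among the measured compounds shown here, no measured step covers this change directly. Compound 1 does carry the acetylsulfamoyl group, but it differs from compound 4 in more than one place, so only its value can be read beside that of compound 3, and the two lie within the scatter of one another.

On that basis the expectation for compound 4 is a step of a 1.1-fold higher number from compound 3 to compound 4 (0.05 log units; within the scatter), that is, none beyond the scatter. The estimate for compound 4 in this assay is 20000 nM, within a range from 8000 nM to 50000 nM.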

Compound 4, concentration for 50% growth inhibition: 38500 nM
Estimate against measurement, compound 4: 1.9-fold (0.28 log units) below; measured number inside the range.
By their numbers in this assay, from the lowest: compounds 3, 1 and 4 (each within the scatter of the next, the first and the last beyond it); then compound 2.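

In this assay, acetyl in place of hydrogen on a sulfonamide nitrogen now has a measured step of its own (a 2.2-fold higher number from compound 3 to compound 4 (0.34 log units; beyond the scatter)), which shows that this position accepts the acetyl group with only a modest weakening of growth inhibition, just beyond the usual scatter. With the acetylsulfamoyl group held constant, 2,5-dihydroxyphenyl in place of 2,5-dimethoxyphenyl on an aromatic carbon gives a step that stays within the scatter (a 2.0-fold higher number from compound 1 to compound 4 (0.30 log units; within the scatter)), so this read-out does not separate these two groups when the sulfonamide nitrogen carries acetyl. Nothing available here accounts for either step.

The compounds shown leave open whether the result is particular to acetyl or would also hold for a longer chain such as butanoyl, or for a methanesulfonyl group or a carboxylic acid placed on the same sulfonamide nitrogen. They also leave open whether acetyl on this nitrogen would give a step of similar size in compound 2, which has hydrogen where compound 3 has chloro.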